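The source may hold more compounds than are shown below. What is called first, only, known or untested is meant among the compounds shown, and "the series" means these compounds.

Working notes on the series. In a functional assay on HeLa cells (Homo sapiens) for cytotoxicity, read by MTT assay (a higher number here means a weaker inhibitor, a lower number a stronger inhibitor), compound 2 `COCCO[C@H](CC=C(C)C)C1=CC(=O)c2c(O)ccc(O)c2C1=O` gives 62400 nM. Compound 1 `CC(C)=CC[C@@H](OC(=O)c1ccco1)C1=CC(=O)c2c(O)ccc(O)c2C1=O` gives 80300 nM, and compound 3 `CCCC(CC(=O)O[C@H](CC=C(C)C)C1=CC(=O)c2c(O)ccc(O)c2C1=O)OC(C)=O` gives 51200 nM. These three values lie within the scatter of one another, so compound 2 holds no distinct rank among them.

Compound 4 `CC(=O)OC(C)CO[C@H](CC=C(C)C)C1=CC(=O)c2c(O)ccc(O)c2C1=O` departs from compound 2 as follows: 1-acetoxyethyl in place of methoxymethyl on a saturated chain carbon bound to an oxygen on a saturated carbon. In words, 1-acetoxyethyl stands in place of methoxymethyl on a saturated chain carbon bound to an oxygen on a saturated carbon. Cut one bond further out, this reads 2-methoxyethyl to 2-acetoxypropyl.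

For the measured compounds named here, no measured step makes this exact change, so the evidence is indirect. Replacing (furan-2-yl)carbonyl with 2-methoxyethyl gave a 1.3-fold lower number from compound 1 to compound 2 (0.11 log units; within the scatter). Placing 2-acetoxypentyl in place of furan-2-yl on a carbonyl carbon gave a 1.6-fold lower number from compound 1 to compound 3 (0.20 log units; within the scatter). Both steps stay within the scatter, although each alters the same oxygen-bound side of the molecule. The 2-acetoxypentyl group of compound 3 is the nearest measured precedent for an acetoxy-bearing chain, at 51200 nM.

No change beyond the scatter is therefore expected in this assay. The expected step is a 1.1-fold lower number from compound 2 to compound 4 (0.05 log units; within the scatter). For compound 4 the estimated value is 56000 nM, with an expected range of 30000 nM to 100000 nM.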

Compound 4, half-maximal inhibitory concentration: 40100 nM
Estimate against measurement, compound 4: 1.4-fold (0.15 log units) above; low and high end bracket the measured number.
By their numbers in this assay, from the lowest: compounds 4, 3, 2 and 1 (each within the scatter of the next).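

In this assay the step on this chain, with 1-acetoxyethyl (6 heavy atoms) in place of methoxymethyl (3 heavy atoms) on a saturated chain carbon bound to an oxygen on a saturated carbon, gives a 1.6-fold lower number from compound 2 to compound 4 (0.19 log units; within the scatter) and thus shows that this position accepts the larger acetoxy-bearing group with no change beyond the scatter. Placing 2-acetoxypropyl in place of (furan-2-yl)carbonyl on an oxygen on a saturated carbon gives a 2.0-fold lower number from compound 1 to compound 4 (0.30 log units; within the scatter), which is also printed as within the scatter, so neither the ester of compound 1 nor the methoxy ether of compound 2 separates from the acetoxy ether of compound 4 in this series. No accompanying measurement bears on these results, so the numbers can be reported but not explained.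

From the compounds shown here alone, it remains open whether any group on this chain moves the number beyond the scatter, for example a primary amine or a carboxylic acid in place of the acetoxy group. Going by these compounds, it also remains open whether a free hydroxyl or a longer chain at this place would do so.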